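This account rests on a few compounds, and the source may have more. Where it says the series, first, only, none or still open, it means among the compounds named here.

In a functional assay on HEK293 cells (Homo sapiens) for cytotoxicity (on this read-out lower numbers stand for higher toxicity in this test and higher numbers for lower toxicity in this test), compound 1 (`COc1ccc([C@H]2CC(=O)N(c3cccc(O)c3)C2)cc1OC1CCCC1`) gives > 10000 nM, a limit of the assay and not a number. Compound 2 (`COc1ccc([C@H]2CC(=O)N(c3cccc(NCc4ccoc4)c3)C2)cc1OC1CCCC1`) gives > 10000 nM, also a limit. Among the measured compounds shown here, compound 2 therefore has no numerical position, and the series so far stands at the limit of > 10000 nM in this assay, at which 2 of the 2 values shown sit.

Compound 3 (`CCCCNc1cccc(N2C[C@@H](c3ccc(OC)c(OC4CCCC4)c3)CC2=O)c1`) has propyl in place of furan-3-yl on a saturated chain carbon bound to a nitrogen on an aromatic ring, so that (furan-3-yl)methyl becomes butyl: propyl in place of furan-3-yl on a saturated chain carbon bound to a nitrogen on an aromatic ring.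

For the measured compounds named here, the only measured step is a step that the two limits leave unreadable from compound 1 to compound 2, and it supplies no size to carry over. Going by the values given here, with that step as the sole guide, no change beyond the scatter is expected in this assay, and no direction can be assigned. The estimated step is a step that the limit leaves unreadable from compound 2 to compound 3. For compound 3 the expected value is 20000 nM, with an estimated range of 10000 nM to 40000 nM.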

Compound 3, half-maximal cytotoxic concentration: > 10000 nM
Compound 3: only a limit was reported (the forecaster's own chance of this, stated with the estimate: 90%); the middle value is on the limit's open side.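

Compound 1, compound 2 and compound 3 yield no readable step between them, as each value is a limit and not a number: the limit of > 10000 nM in this assay, at which 3 of the 3 values shown sit.

The compounds shown leave open how hydroxy, ((furan-3-yl)methyl)amino and butylamino on the shared core compare in this assay.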